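Shifting the Indole Attachment on the Amine Nitrogen

The source may hold more compounds than are shown below. What is called first, only, known or untested is meant among the compounds shown, and "the series" means these compounds.

In a functional assay on A549 cells (Homo sapiens) for cytotoxicity, read by MTT assay, with a stated time of 48 h (a lower number here means a stronger inhibitor, a higher number a weaker inhibitor), compound 1 (`COc1ccc(-c2nc3ccccn3c2C(=O)/C=C\Nc2cc(OC)cc(OC)c2)cc1`) gives 4470 nM, and compound 2 (`COc1ccc(-c2nc3ccccn3c2C(=O)/C=C\Nc2ccc3[nH]ccc3c2)cc1`) gives 11000 nM. Compound 2 therefore holds the higher number of the two, which makes it the weaker inhibitor so far. Compound 3 (`COc1ccc(-c2nc3ccccn3c2C(=O)/C=C\Nc2ccc3cc[nH]c3c2)cc1`) has not yet been measured. It has the same atoms as compound 2, joined differently: 1H-indol-6-yl in place of 1H-indol-5-yl on an amine nitrogen. Put simply, 1H-indol-6-yl stands in place of 1H-indol-5-yl on an amine nitrogen.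

Within the data shown here, only one measured step bears on this change, and it bears only loosely. The exchange of 3,5-dimethoxyphenyl for 1H-indol-5-yl gave a 2.5-fold higher number from compound 1 to compound 2 (0.39 log units; beyond the scatter), a modest step beyond the scatter, even though it replaced one group with a quite different one. Among the measured compounds shown here, compound 3 keeps the indole and changes only where it is attached, and no measured pair shows what such a shift does. A smaller change is therefore expected, with none beyond the scatter. The expected step is a 1.2-fold lower number from compound 2 to compound 3 (0.09 log units; within the scatter). For compound 3 the estimate is 9000 nM, with an expected range from 4000 nM to 20000 nM.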

Compound 3, half-maximal inhibitory concentration: 8800 nM
Compound 3: the middle estimate sits 1.0-fold (0.01 log units) above what was measured; measured number inside the range.
By their numbers in this assay, from the lowest: compounds 1, 3 and 2 (each within the scatter of the next, the first and the last beyond it).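

Shifting the attachment from 1H-indol-5-yl to 1H-indol-6-yl on the amine nitrogen gives, in this assay, a 1.3-fold lower number from compound 2 to compound 3 (0.10 log units; within the scatter), so this assay cannot tell the two indoles apart, and at this position the point of attachment shows no measurable effect. The comparison with the 3,5-dimethoxyphenyl group also becomes less clear-cut: the 1H-indol-5-yl group gave a 2.5-fold higher number from compound 1 to compound 2 (0.39 log units; beyond the scatter), just beyond the scatter, whereas the 1H-indol-6-yl group gives a 2.0-fold higher number from compound 1 to compound 3 (0.29 log units; within the scatter), just within it. The case for the dimethoxyphenyl group outperforming the indoles therefore rests on one narrow gap and does not hold for both attachments, and no measurement is available that could account for any of these numbers.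

The compounds shown leave open whether a 1H-indol-4-yl group or a plain phenyl group on the same amine nitrogen would give a similar number. They also leave open whether a 1-methyl-1H-indol-5-yl group, with a methyl in place of the indole's hydrogen on nitrogen, would stay level with the two indoles.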